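Hydroxy in place of methylsulfanyl: compound 3 to compound 4

A few compounds are considered here, and "the series" means these few. Any claim that something is new, unique, unknown or untested is made for them only; others in the source may bear on it.

Compound 3 `CCCc1ncc2c(C)nnc(SC)n12` is the methylsulfanyl member of the series. In a functional assay for inhibition, with Homo sapiens as the target (a lower number here means a stronger inhibitor, a higher number a weaker inhibitor), compound 3 gives > 48000 nM, which is a limit of the assay and not a number. Compound 2 `CCCc1ncc2c(C)nnc(S)n12` in this assay gives > 48000 nM, likewise a limit. Compound 1 `CCCc1ncc2cnnc(O)n12`, which also carries a hydroxy group but lacks the methyl, in this assay gives > 48000 nM, again a limit. Going by the values given here, the single step between measured neighbours, a step that the two limits leave unreadable from compound 2 to compound 3, stays unreadable because of the limit of > 48000 nM in this assay, at which 3 of the 3 values shown sit.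

Compound 4 `CCCc1ncc2c(C)nnc(O)n12` has not yet been measured. It differs from compound 3 by hydroxy in place of methylsulfanyl on an aromatic carbon. Among the compounds with values here, no measured step gives a readable size for this change. The nearest comparisons are compound 1, which already carries the hydroxy group, and compound 2, and both sit at the limit, as does compound 3. No step beyond the scatter is expected.

Compound 4 is expected to remain at the limit, a step that the limit leaves unreadable from compound 3 to compound 4. The estimate for compound 4 in this assay is 60000 nM, with a range from 30000 nM to 200000 nM.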

Compound 4, half-maximal inhibitory concentration: > 48000 nM
Compound 4: no number, only a limit (the forecaster's own chance of this, stated with the estimate: 85%); the middle value lies beyond the limit too.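

Compound 4, like compound 1, compound 2 and compound 3, yields no readable step in this assay, and all steps among them stay unreadable because of this: the limit of > 48000 nM in this assay, at which 4 of the 4 values shown sit.

The compounds shown leave open which change to the shared core, if any, would bring a value inside the range of the assay.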